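A Furanyl Variant of a Prostaglandin D2 Receptor 2 Ligand

This account rests on a few compounds, and the source may have more. Where it says the series, first, only, none or still open, it means among the compounds named here.

Measured compounds:
compound 1, `O=C(O)Cc1sc(CSc2ccccc2)nc1-c1ccc(Cl)cc1`, 250 nM
compound 2, `O=C(O)Cc1sc(C(c2ccc(F)cc2)c2ccc(F)cc2)nc1-c1cc(F)cc(F)c1`, 35 nM

Of the compounds shown here, two have been measured in an in vitro assay on HEK385-7 cells for displacement of a labelled ligand from prostaglandin D2 receptor 2 (Homo sapiens); on this read-out higher numbers stand for weaker inhibition and lower numbers for stronger inhibition: compound 1 gives 250 nM, while compound 2 gives 35 nM. Compound 2 therefore holds the lower of the two numbers, and compound 1 stands well above it, with a gap that lies beyond the usual scatter of repeated measurements. The two compounds differ in several places at once, so nothing can be said about which change carries that gap.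

The next compound, compound 3 (`O=C(O)Cc1sc(C(c2ccc(F)cc2)c2ccc(F)cc2)nc1-c1ccoc1`), departs from compound 2 in a single place: furan-3-yl in place of 3,5-difluorophenyl on an aromatic carbon. Among the measured compounds shown here, no pair of measured compounds differing in one place exists in this set, so there is no measured guide to the size of such a step. For the measured compounds named here, with the 3,5-difluorophenyl group of compound 2 giving the lowest number so far, the change is expected to cost some potency, and the step from compound 2 to compound 3 in this assay is estimated at a 2.9-fold higher number from compound 2 to compound 3 (0.46 log units; beyond the scatter). Compound 3 is accordingly expected to show 100 nM, within a range from 35 nM to 300 nM.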

Compound 3, half-maximal inhibitory concentration: 14 nM
Estimate against measurement, compound 3: 7.1-fold (0.85 log units) above, outside the stated range (below it).
By their numbers in this assay, from the lowest: compound 3; then compound 2; then compound 1.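

The change of furan-3-yl in place of 3,5-difluorophenyl gives a 2.5-fold lower number from compound 2 to compound 3 (0.40 log units; beyond the scatter) in this assay and is a modest step, yet it is the only single-place comparison shown and the first measured size for a step at this aromatic carbon, next to the ring nitrogen and next to the ring atom that bears a carboxymethyl group. It shows that the 3,5-difluorophenyl group, with 8 heavy atoms and two fluorines, is not needed here for a low number, since furan-3-yl, with 5 heavy atoms and one ring oxygen, gives a lower one. No measurement at hand bears on why the number falls.

The compounds shown leave open whether the ring oxygen or the smaller ring goes with the lower number, a question that furan-2-yl, thiophen-3-yl or an unsubstituted phenyl at this carbon would help to separate. They also leave open whether the step would hold with a phenylthiomethyl group in place of the large group that compound 2 and compound 3 share.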